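The source may report more compounds than this note shows. Statements on the series, on what has been measured and on what is new or still open speak of the compounds shown alone.

Compound 1 `COc1ccc(Cl)cc1C(=O)NCCC1CCN(S(=O)(=O)NC(=O)NC[C@@H]2C[C@@H]3C=C[C@@H]2C3)CC1` carries the 5-chloro-2-methoxyphenyl on the carbonyl carbon; compound 2 `CC(=O)NCCC1CCN(S(=O)(=O)NC(=O)NC[C@@H]2C[C@@H]3C=C[C@@H]2C3)CC1` has a methyl and compound 3 `O=C(NC[C@@H]1C[C@@H]2C=C[C@@H]1C2)NS(=O)(=O)N1CCC(CCNC(=O)C(F)(F)F)CC1` a trifluoromethyl at that place, the rest of the core being shared. In a functional assay on the whole organism (blood) with Rattus norvegicus as the target, with stated times of 24 h and 1 h, at a dose of 5 mg/kg by the intraperitoneal route (on this read-out higher numbers stand for a stronger effect at the one dose given and lower numbers for a weaker effect), compound 1 gives 37%, compound 2 gives 18% and compound 3 gives 22%. Compound 3 thus stands second highest of the three numbers, its value and that of compound 2 lying within the scatter of one another, while compound 1 sits higher by a margin beyond it; the first of those gaps is a number 19 percentage points lower from compound 1 to compound 2 (beyond the scatter).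

Compound 4 `Cc1ncsc1C(=O)NCCC1CCN(S(=O)(=O)NC(=O)NC[C@@H]2C[C@@H]3C=C[C@@H]2C3)CC1` is the next member and differs from compound 3 in one place: 4-methyl-1,3-thiazol-5-yl in place of trifluoromethyl on a carbonyl carbon. The step bearing most directly on it is a number 15 percentage points lower from compound 1 to compound 3 (beyond the scatter), an exchange of an aromatic ring for trifluoromethyl on the carbonyl carbon, while a number 4 percentage points higher from compound 2 to compound 3 (within the scatter) shows that methyl and trifluoromethyl do not separate. Read in the opposite direction, that suggests a modest rise for compound 4 in this assay, though the entering ring is not the one carried by compound 1, so the size remains uncertain. The step expected here is a number 9 percentage points higher from compound 3 to compound 4 (within the scatter). Compound 4 is estimated at 31%, with a range from 18% to 45%.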

Compound 4, a percentage reported as activity, at one dose (the size of the read-out at that dose, not a potency): 11%
Estimate against measurement, compound 4: 20 percentage points above; measured number below the stated range.
By their numbers in this assay, from the lowest: compounds 4, 2 and 3 (each within the scatter of the next, the first and the last beyond it); then compound 1.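

Working notes on the group on the carbonyl carbon: an aromatic ring at this place does not by itself keep the higher read-out of compound 1, since in this assay the two rings separate (a number 26 percentage points lower from compound 1 to compound 4 (beyond the scatter)). The 4-methyl-1,3-thiazol-5-yl group also falls short of trifluoromethyl (a number 11 percentage points lower from compound 3 to compound 4 (beyond the scatter)), yet it does not separate from methyl (a number 7 percentage points lower from compound 2 to compound 4 (within the scatter)), so the three compounds without the 5-chloro-2-methoxyphenyl group form a low cluster in which only the gap between the thiazole and trifluoromethyl exceeds the scatter. No measured property of these compounds is available to account for the gap between the two rings.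

The compounds shown leave open whether the read-out of compound 1 depends on the phenyl ring itself or on its chloro and methoxy substituents, a question that plain phenyl, 5-chlorophenyl and 2-methoxyphenyl would address directly. They also leave open how a pyridine ring, or a non-aromatic group such as a cyclohexyl or an aminomethyl on the carbonyl carbon, would fall relative to this cluster.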